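A few compounds are considered here, and "the series" means these few. Any claim that something is new, unique, unknown or untested is made for them only; others in the source may bear on it.

Working notes on the series.

Compound 1 `COc1ccc(C2=NN(C3=NC(=O)/C(=C4\C(=O)Nc5ccc(Br)cc54)S3)C(c3ccc(OC)cc3)C2)cc1` and compound 2 `COc1ccc(C2CC(c3ccc4ccccc4c3)=NN2C2=NC(=O)/C(=C3\C(=O)Nc4ccc(Br)cc43)S2)cc1` share one core; compound 3 `COc1ccc(C2=NN(C3=NC(=O)/C(=C4\C(=O)Nc5ccccc54)S3)C(c3ccc(Cl)cc3)C2)cc1` and the as yet unmeasured compound 4 `O=C1N=C(N2N=C(c3ccc4ccccc4c3)CC2c2ccc(Cl)cc2)S/C1=C1/C(=O)Nc2ccccc21` share another. The difference between the two cores is not broken down here.

In a functional assay on cells (Cancer cell lines, Homo sapiens) for cytotoxicity, read by sulforhodamine B assay, with a stated time of 48 h (a lower number here means a stronger inhibitor of growth, a higher number a weaker inhibitor of growth), compound 1 gives 710 nM. Compound 2 gives 510 nM in this assay, and the change that carries one to the other, (naphthalen-2-yl in place of 4-methoxyphenyl on a carbon with a double bond to nitrogen), produced a 1.4-fold lower number from compound 1 to compound 2 (0.14 log units; within the scatter). In this assay compound 3 gives 100000 nM, the highest number of the three measured compounds, far from the other two.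

The change from compound 3 to compound 4 is naphthalen-2-yl in place of 4-methoxyphenyl on a carbon with a double bond to nitrogen. Going by the values given here, it is the same kind of change as the one from compound 1 to compound 2, not the same: in the earlier pair the ring atom two ring bonds away bears a 4-methoxyphenyl group, here it bears a 4-chlorophenyl group. Among the compounds with values here, the only measured instance of this exchange is the step of a 1.4-fold lower number from compound 1 to compound 2 (0.14 log units; within the scatter), which stayed within the scatter, so a small step is expected from compound 3 to compound 4 as well, estimated as a 1.7-fold lower number from compound 3 to compound 4 (0.22 log units; within the scatter). Because compound 3 gives 100000 nM, compound 4 is expected to remain a weak inhibitor of growth, estimated at 60000 nM in this assay, with a range expected from 15000 nM to 100000 nM. The reported number for compound 3 sits where this assay may report only a limit, and the same is possible for compound 4.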

Compound 4, concentration for total growth inhibition: 50700 nM
Estimate against measurement, compound 4: 1.2-fold (0.07 log units) above, and the stated range covers the measured number.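

In this assay, the exchange of 4-methoxyphenyl for naphthalen-2-yl gives a 2.0-fold lower number from compound 3 to compound 4 (0.29 log units; within the scatter), and the two cores do not differ in their response to it: the same change on two cores in this assay, a 1.4-fold lower number (0.14 log units; within the scatter) from compound 1 to compound 2 and a 2.0-fold lower number (0.29 log units; within the scatter) from compound 3 to compound 4, 1.4-fold (0.15 log units) apart, within the scatter of two such steps. The exchange therefore carries over as a small step in both pairs, on the core of compound 1 and on the core of compound 3, where the numbers are far higher. This does not show that naphthalen-2-yl is better or worse than 4-methoxyphenyl at this carbon, as both steps stay within the scatter, and two pairs set no rule for other cores, while the number of compound 3 may be only a limit of the assay, which would leave the size of the second step uncertain.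

Still open, from the compounds shown here alone, is whether the large gap between the two cores goes with the bromine of compound 1 and compound 2, with the 4-chlorophenyl group of compound 3 and compound 4, or with both together. Also open, going by these compounds, is whether the flat response at the carbon with a double bond to nitrogen would hold for a group of another kind there, such as a cyclohexyl ring, a pyridine ring or a phenyl ring carrying a dimethylamino group.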